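Same amine swap carried onto the trimethylphenyl core

The source may report more compounds than this note shows. Statements on the series, on what has been measured and on what is new or still open speak of the compounds shown alone.

Measured so far in an assay on HEK293 cells for binding affinity to corticotropin-releasing factor receptor 1 (Homo sapiens), read by radioligand binding; a lower number here means a stronger inhibitor, a higher number a weaker inhibitor:

compound 1 `CCCN(CC1CC1)c1nc(C)nc2c1n(C)c(=O)n2-c1ccc(C(C)C)cc1Br` gives 5.7 nM
compound 2 `CCCCC(CC)Nc1nc(C)nc2c1n(C)c(=O)n2-c1ccc(C(C)C)cc1Br` gives 15.1 nM
compound 3 `CCCN(CC1CC1)c1nc(C)nc2c1n(C)c(=O)n2-c1c(C)cc(C)cc1C` gives 6.1 nM

Two single changes connect these three. From compound 1 to compound 2 the change is (1-ethylpentyl)amino in place of (cyclopropylmethyl)(propyl)amino on an aromatic carbon and the step in this assay is a 2.6-fold higher number from compound 1 to compound 2 (0.42 log units; beyond the scatter). From compound 1 to compound 3 the change is 2,4,6-trimethylphenyl in place of 2-bromo-4-isopropylphenyl on an aromatic nitrogen and the step is a 1.1-fold higher number from compound 1 to compound 3 (0.03 log units; within the scatter), so compound 1 and compound 3 cannot be told apart in this assay. Compound 2 and compound 3 have not been compared as a step; their two values simply show compound 2 with the higher number.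

Compound 4 `CCCCC(CC)Nc1nc(C)nc2c1n(C)c(=O)n2-c1c(C)cc(C)cc1C` is not yet measured. It differs from compound 3 by (1-ethylpentyl)amino in place of (cyclopropylmethyl)(propyl)amino on an aromatic carbon. The place of this change is described in the same words as for the change from compound 1 to compound 2, so it is the same change, now made on the core of compound 3 rather than the core of compound 1; how the two cores differ is given above as 2,4,6-trimethylphenyl in place of 2-bromo-4-isopropylphenyl on an aromatic nitrogen.

With one prior example of the change, the expectation for compound 3 to compound 4 is an estimated step of a 2.6-fold higher number from compound 3 to compound 4 (0.42 log units; beyond the scatter), resting on compound 1 to compound 2 having given a 2.6-fold higher number from compound 1 to compound 2 (0.42 log units; beyond the scatter). Compound 4 is therefore expected to give about 16 nM in this assay, estimated between 7 nM and 36 nM.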

Compound 4, inhibition constant: 17.4 nM
Estimate against measurement, compound 4: 1.1-fold (0.04 log units) below, and the stated range covers the measured number.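

In this assay, (1-ethylpentyl)amino in place of (cyclopropylmethyl)(propyl)amino on the core of compound 3 gives a 2.9-fold higher number from compound 3 to compound 4 (0.46 log units; beyond the scatter), and this step matches the one seen on the core of compound 1: the same change on two cores in this assay, a 2.6-fold higher number (0.42 log units; beyond the scatter) from compound 1 to compound 2 and a 2.9-fold higher number (0.46 log units; beyond the scatter) from compound 3 to compound 4, 1.1-fold (0.03 log units) apart, within the scatter of two such steps

With (1-ethylpentyl)amino present, 2,4,6-trimethylphenyl in place of 2-bromo-4-isopropylphenyl gives a 1.2-fold higher number from compound 2 to compound 4 (0.06 log units; within the scatter), which again matches the earlier step: the same change on two cores in this assay, a 1.1-fold higher number (0.03 log units; within the scatter) from compound 1 to compound 3 and a 1.2-fold higher number (0.06 log units; within the scatter) from compound 2 to compound 4, 1.1-fold (0.03 log units) apart, within the scatter of two such steps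

Within these four compounds, each change therefore carried from one core to the other with no detectable dependence on the other change, but this rests on only two amino groups and two aryl groups and does not show why the amine change raises the number or that the agreement extends to other groups.

Still open, as far as these compounds go, is whether the same step would appear with a dipropylamino or bis(2-methoxyethyl)amino group in place of (1-ethylpentyl)amino. Also open, from the compounds shown here alone, is whether a 2,4-dichlorophenyl group on the aromatic nitrogen would fit the same pattern.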